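The source may report more compounds than this note shows. Statements on the series, on what has been measured and on what is new or still open speak of the compounds shown alone.

Measured in a functional assay on HeLa cells (Homo sapiens) for cytotoxicity, read by sulforhodamine B assay; on this read-out higher numbers stand for weaker inhibition and lower numbers for stronger inhibition:
compound 1, `Cn1c2c(c3ccccc3c1=O)CCOc1ccccc1-2`, gives 19700 nM
compound 2, `Cc1ccc2c3c(n(C)c(=O)c2c1)-c1ccccc1OCC3`, gives 8760 nM
compound 3, `C=COc1ccccc1-c1c(Br)c2ccccc2c(=O)n1Cc1ccc(OC)cc1`, gives 36500 nM

Compounds 1 and 2 share one core and differ in a single place: methyl in place of hydrogen on an aromatic carbon. That change brought a 2.2-fold lower number from compound 1 to compound 2 (0.35 log units; beyond the scatter). Compound 3 is built on a different core; the difference between the two cores is not broken down here. Compound 4, `C=COc1ccccc1-c1c(Br)c2cc(C)ccc2c(=O)n1Cc1ccc(OC)cc1`, has not yet been measured. It differs from compound 3 in one place: methyl in place of hydrogen on an aromatic carbon. For the measured compounds named here, this is the same kind of change as the one from compound 1 to compound 2, though not the same change: in compound 2 the altered ring is part of a fused or bridged system of four rings, whereas in compound 4 it is part of a fused or bridged system of two rings. Because the earlier change gave a 2.2-fold lower number from compound 1 to compound 2 (0.35 log units; beyond the scatter), a step of about the same size is expected for compound 4, namely a 2.1-fold lower number from compound 3 to compound 4 (0.33 log units; beyond the scatter). On that basis compound 4 is estimated at 17000 nM in this assay, with the likely range running from 8000 nM to 40000 nM.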

Compound 4, half-maximal inhibitory concentration: 14800 nM
The estimate for compound 4 lay 1.1-fold (0.06 log units) above the measured number, and the stated range covers the measured number.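

In this assay, methyl in place of hydrogen on an aromatic carbon brought a 2.5-fold lower number from compound 3 to compound 4 (0.39 log units; beyond the scatter) on the core of compound 3, so the number moved the same way as it did on the core of compound 1. Set side by side, the two steps match in size, so in this small series the change carried over from one core to the other, even though the altered ring sits in a fused system of four rings in compound 2 and of two rings in compound 4: the same change on two cores in this assay, a 2.2-fold lower number (0.35 log units; beyond the scatter) from compound 1 to compound 2 and a 2.5-fold lower number (0.39 log units; beyond the scatter) from compound 3 to compound 4, 1.1-fold (0.04 log units) apart, within the scatter of two such steps. For the compounds shown here, this rests on only two pairs of compounds in a single cell assay, so it does not show that the step would hold on any further core, and it does not explain why the number falls.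

The compounds shown leave open whether an ethyl group, a longer chain, an amine or a carboxylic acid in that same place would move the number in the same way. They also leave open what methyl would do on another carbon of that ring.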